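The source may hold more compounds than are shown below. What is called first, only, known or untested is meant among the compounds shown, and "the series" means these compounds.

Measured compounds:
compound 1 `CN(C)CCn1cnnc1-c1cc(Oc2ccc(NC(=O)N/N=C/c3ccccc3)cc2F)ccn1` — 2730 nM
compound 2 `CN(C)CCn1cnnc1-c1cc(Oc2ccc(NC(=O)N/N=C/c3ccc(Cl)cc3)cc2F)ccn1` — 570 nM

In a functional assay on MKN-45 cells (Homo sapiens) for cytotoxicity, read by MTT assay, with a stated time of 72 h (a higher number here means a weaker inhibitor, a lower number a stronger inhibitor), compound 1 gives 2730 nM and compound 2 gives 570 nM. For the measured compounds named here, compound 2 holds the lower of the two numbers; the only measured step, a 4.8-fold lower number from compound 1 to compound 2 (0.68 log units; beyond the scatter), separates the two, and it is the sole point of reference for the series so far.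

Compound 3 `CN(C)CCn1cnnc1-c1cc(Oc2ccc(NC(=O)N/N=C/c3ccc(O)cc3O)cc2F)ccn1` has not been measured. It differs from compound 2 by 2,4-dihydroxyphenyl in place of 4-chlorophenyl on a carbon with a double bond to nitrogen.

Going by the values given here, no measured step bears on this change directly. Among the compounds with values here, the one step known, a 4.8-fold lower number from compound 1 to compound 2 (0.68 log units; beyond the scatter), concerns the chloro that now leaves; its reversal alone would be expected to push the number back toward that of compound 1. What the two hydroxyls that enter do is not covered by any measured pair, so the direction beyond that reversal is open. The expectation is therefore a step of a 3.5-fold higher number from compound 2 to compound 3 (0.55 log units; beyond the scatter), with a wide range. For compound 3 the estimated value in this assay is 2000 nM, between 500 nM and 8000 nM.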

Compound 3, half-maximal inhibitory concentration: 2860 nM
Estimate against measurement, compound 3: 1.4-fold (0.16 log units) below; the range from low to high includes it.
By their numbers in this assay, from the lowest: compound 2; then compounds 1 and 3 (each within the scatter of the next).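

In this assay, replacing 4-chlorophenyl with 2,4-dihydroxyphenyl on the carbon with a double bond to nitrogen gives a 5.0-fold higher number from compound 2 to compound 3 (0.70 log units; beyond the scatter), so the lower number of compound 2 does not carry over to this hydroxylated ring. Against the unsubstituted phenyl, the same group gives a 1.0-fold higher number from compound 1 to compound 3 (0.02 log units; within the scatter), which places the two hydroxyls level with hydrogen in this assay and leaves 4-chlorophenyl as the only one of the three groups at this position that stands apart from the others. No measurement available here accounts for the difference between 4-chlorophenyl and 2,4-dihydroxyphenyl.

Going by these compounds, it remains open whether the lower number of compound 2 is specific to chlorine, which 4-bromophenyl or 4-methoxyphenyl in place of 4-chlorophenyl could test. The contribution of each hydroxyl also remains unresolved, since compound 3 carries both together and only 4-hydroxyphenyl or 2-hydroxyphenyl at the same place could separate them.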